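Chloro for methoxy on a weak neuropeptide Y antagonist scaffold

This account rests on a few compounds, and the source may have more. Where it says the series, first, only, none or still open, it means among the compounds named here.

Compound 1 `COc1ccc2c(c1)CC(NCC1CCN(CCNS(=O)(=O)c3cccc4ccccc34)CC1)CCC2` is one of two measured members of this series. In an assay on isolated protein for inhibition of Neuropeptide Y receptor type 1 (Homo sapiens) (a higher number here means a weaker inhibitor, a lower number a stronger inhibitor), compound 1 gives 14000 nM, the lower of the two numbers recorded. Among the compounds with values here, its only neighbour is compound 2 `COc1cc2c(cc1OC)CC(NCC1CCN(CCNS(=O)(=O)c3cccc4ccccc34)CC1)CCC2`, which carries an added methoxy on an aromatic carbon and gives 17000 nM in this assay; the step from compound 1 to compound 2 amounts to a 1.2-fold higher number from compound 1 to compound 2 (0.08 log units; within the scatter).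

Compound 3 `O=S(=O)(NCCN1CCC(CNC2CCCc3ccc(Cl)cc3C2)CC1)c1cccc2ccccc12` has not yet been measured. It differs from compound 1 by chloro in place of methoxy on an aromatic carbon. Within the data shown here, no measured pair shows a chloro entering in place of a methoxy, so the one step available, a 1.2-fold higher number from compound 1 to compound 2 (0.08 log units; within the scatter), bears on it only indirectly: it shows that adding a methoxy to this ring left the number unchanged beyond the scatter, suggesting the substituent pattern on this ring is not a strong lever here. On that basis the step from compound 1 to compound 3 is expected to be small, a 1.2-fold lower number from compound 1 to compound 3 (0.07 log units; within the scatter), in no clear direction. Compound 3 is therefore estimated to give 12000 nM in this assay, with a plausible range from 3500 nM to 40000 nM.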

Compound 3, half-maximal inhibitory concentration: 8500 nM
For compound 3 the middle estimate is 1.4-fold (0.15 log units) above the measured one; low and high end bracket the measured number.
By their numbers in this assay, from the lowest: compounds 3, 1 and 2 (each within the scatter of the next).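

In this assay, within the data shown here, the step of a 1.6-fold lower number from compound 1 to compound 3 (0.22 log units; within the scatter) gives the first direct reading at this aromatic carbon, meta to a fused ring and para to a fused ring, where one substituent replaces another rather than being added. The exchange removes methoxy, with its 2 heavy atoms and 1 hydrogen-bond acceptor, and puts in chloro, with 1 heavy atom and 0 hydrogen-bond acceptors, yet the step stays within the scatter, so in this pair neither the loss of the acceptor nor the change of atom type separates the two compounds. Nothing shown explains why this exchange leaves compound 3 within the scatter of compound 1.

Going by these compounds, it remains open whether this tolerance extends to groups of a different kind on the same aromatic carbon, such as an amine or a carboxylic acid, which could show whether this position can move the number beyond the scatter at all. On these data alone, it is also open whether chloro and methoxy would still be indistinguishable if the shared core were changed elsewhere, for instance by a longer chain.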